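A few compounds are considered here, and "the series" means these few. Any claim that something is new, unique, unknown or untested is made for them only; others in the source may bear on it.

Compound 1, `O=C1O[C@H]([C@@H](O)Cn2cc(CNS(=O)(=O)c3ccc(F)cc3)nn2)C(OCc2ccccc2)=C1OCc1ccccc1`: 41100 nM
Compound 2, `O=C1O[C@H]([C@@H](O)Cn2cc(C3CC3)nn2)C(OCc2ccccc2)=C1OCc1ccccc1`: 54200 nM
Compound 3, `C[Si](C)(C)c1cn(C[C@H](O)[C@H]2OC(=O)C(OCc3ccccc3)=C2OCc2ccccc2)nn1`: 56000 nM

In a functional assay on SW-620 cells (Homo sapiens) for antiproliferative activity, read by MTT assay, with a stated time of 72 h (a higher number here means a weaker inhibitor, a lower number a stronger inhibitor), compound 1 gives the lowest of the three numbers, yet both neighbours sit within the scatter of it: a 1.3-fold higher number from compound 1 to compound 2 (0.12 log units; within the scatter) and a 1.4-fold higher number from compound 1 to compound 3 (0.13 log units; within the scatter). Compound 4, `O=C1O[C@H]([C@@H](O)Cn2cc(CNS(=O)(=O)c3ccc(Cl)cc3F)nn2)C(OCc2ccccc2)=C1OCc1ccccc1`, differs from compound 1 by 4-chloro-2-fluorophenyl in place of 4-fluorophenyl on a sulfonyl sulfur. For the measured compounds named here, no measured step touches the aryl group on the sulfonyl. The steps that exchange groups on the aromatic carbon of the shared core, a 1.0-fold higher number from compound 2 to compound 3 (0.01 log units; within the scatter) among them, all stay within the scatter, which suggests a small change on an outer ring is expected to leave the number close to where it stands. Compound 4 is expected to show a 1.0-fold higher number from compound 1 to compound 4 (0.01 log units; within the scatter). The estimate for compound 4 in this assay is 42000 nM, with a range from 17000 nM to 105000 nM.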

Compound 4, half-maximal inhibitory concentration: 42400 nM
Estimate against measurement, compound 4: 1.0-fold (0.00 log units) below, and the stated range covers the measured number.
By their numbers in this assay, from the lowest: compounds 1, 4, 2 and 3 (each within the scatter of the next).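

In this assay, the exchange of 4-fluorophenyl for 4-chloro-2-fluorophenyl on the sulfonyl sulfur gives a 1.0-fold higher number from compound 1 to compound 4 (0.01 log units; within the scatter). For the compounds shown here, this is the first measured change to the aryl group on the sulfonyl, and like the earlier exchanges on the aromatic carbon of the shared core, it stays within the scatter. No evidence on hand explains this result. All four compounds remain within the scatter of their nearest neighbours, so no group shown here has moved the number beyond it. On these data alone, whether an amine or a carboxylic acid on this aryl ring, or a longer chain in its place, would do so remains open.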